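Parallel aryl swap on a pyrazoline paw edema series

This account rests on a few compounds, and the source may have more. Where it says the series, first, only, none or still open, it means among the compounds named here.

Compound 1 `COc1ccc(C2=NN(C(=O)CO[N+](=O)[O-])C(c3ccco3)C2)cc1OC` was tested in a functional assay on the whole organism (strain albino) for inhibition, with Rattus norvegicus as the target, read by paw edema, with stated times of 30 min and 2 h, at a dose of 100 mg/kg by the oral route (a higher number here means more inhibition at the dose given (going by the name of the read-out), a lower number less inhibition), and compound 1 gives 37%. Compound 2 `COc1ccc(C2CC(c3ccc(OC)c(OC)c3)=NN2C(=O)CO[N+](=O)[O-])c(OC)c1` differs from it by 2,4-dimethoxyphenyl in place of furan-2-yl on a saturated ring carbon, and in this assay compound 2 gives 48%, a step of a number 11 percentage points higher from compound 1 to compound 2 (beyond the scatter). Compound 3 `COc1ccc(C2=NN(C(=O)CNc3ccc(/C(C)=N/O)cc3)C(c3ccco3)C2)cc1OC` differs from compound 1 by a group of 11 heavy atoms (8 carbon, 2 nitrogen, 1 oxygen; one six-membered aromatic ring of carbon only) in place of a group of 4 heavy atoms (1 nitrogen, 3 oxygen; no ring), on a saturated chain carbon bound to a carbonyl carbon, and in this assay compound 3 gives 46%, a step of a number 9 percentage points higher from compound 1 to compound 3 (within the scatter).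

Compound 4 `COc1ccc(C2CC(c3ccc(OC)c(OC)c3)=NN2C(=O)CNc2ccc(/C(C)=N/O)cc2)c(OC)c1` has not yet been measured. It differs from compound 3 by 2,4-dimethoxyphenyl in place of furan-2-yl on a saturated ring carbon. Among the compounds with values here, this is the same kind of change as the one from compound 1 to compound 2, though the surroundings are not identical: in the earlier pair the saturated ring carbon sits next to the ring atom that bears a ((nitrooxy)methyl)carbonyl group and two ring bonds from the ring atom that bears a large group, whereas in compound 3 it sits next to the ring atom that bears a large group and two ring bonds from the ring atom that bears a 3,4-dimethoxyphenyl group.

Because the same kind of change gave a number 11 percentage points higher from compound 1 to compound 2 (beyond the scatter), compound 4 is expected to move by about a number 8 percentage points higher from compound 3 to compound 4 (within the scatter) in this assay. The estimate for compound 4 is 54%, with a likely span from 40% to 68%.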

Compound 4, a percentage reported as inhibition, in the whole organism at one dose (the size of the read-out at that dose, not a potency): 44%
Beside the measured number, compound 4's estimate is 10 percentage points above it; the measured number falls inside the stated range.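

In this assay, 2,4-dimethoxyphenyl in place of furan-2-yl on the saturated ring carbon gave a number 2 percentage points lower from compound 3 to compound 4 (within the scatter), and this step cannot be told apart from its counterpart on the other core: the same change on two cores in this assay, a number 11 percentage points higher (beyond the scatter) from compound 1 to compound 2 and a number 2 percentage points lower (within the scatter) from compound 3 to compound 4, 13 percentage points apart, within the scatter of two such steps. The exchange of the group on the saturated chain carbon bound to a carbonyl carbon gave a number 4 percentage points lower from compound 2 to compound 4 (within the scatter), and it too cannot be told apart from its earlier counterpart: the same change on two cores in this assay, a number 9 percentage points higher (within the scatter) from compound 1 to compound 3 and a number 4 percentage points lower (within the scatter) from compound 2 to compound 4, 13 percentage points apart, within the scatter of two such steps. Within the data shown here, this shows no measurable dependence of either change on the core, but it does not show that either change carries over, since each rests on a single pair of steps and only one of the four steps lies beyond the scatter.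

The compounds shown leave open how other groups on the saturated ring carbon, such as an unsubstituted phenyl or a thiophen-2-yl, would behave on these two cores. They also leave open whether a carboxylic acid or a longer chain on the carbonyl side would follow the same course, and whether any of these steps would hold at another dose.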